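From Compound 1 to Compound 4 in HeLa Cells

The source may hold more compounds than are shown below. What is called first, only, known or untested is meant among the compounds shown, and "the series" means these compounds.

Of the compounds shown here, three have been tested in a functional assay on HeLa cells (Homo sapiens) for inhibition, read by CCK-8 assay, with a stated time of 48 h; on this read-out lower numbers stand for stronger inhibition and higher numbers for weaker inhibition. Among the compounds with values here, compound 1 `O=S(=O)(NCCNC(=S)Nc1cccc(Cl)c1)c1ccc(-c2ccccc2OCc2cccc(O)c2)s1` gives 10700 nM, the only actual number among the three. Compound 2 `O=C(NCCNS(=O)(=O)c1ccc(-c2ccccc2O[C@H]2CC[C@H](O)CC2)s1)Nc1cc(C(F)(F)F)cc(C(F)(F)F)c1` gives only a limit of the assay, > 20000 nM. Compound 3 `COc1ccc(NC(=O)NCCNS(=O)(=O)c2ccc(-c3ccccc3OCc3ccccc3)s2)cc1` also gives only a limit, > 50000 nM.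

The next compound to be measured is compound 4 `O=C(NCCNS(=O)(=O)c1ccc(-c2ccccc2OCc2cccc(O)c2)s1)Nc1cc(Cl)cc(Cl)c1`. It differs from compound 1 in one place, on an amine nitrogen: a group of 11 heavy atoms (7 carbon, 1 nitrogen, 1 oxygen, 2 chlorine; one six-membered aromatic ring of carbon only) in place of a group of 10 heavy atoms (7 carbon, 1 nitrogen, 1 sulfur, 1 chlorine; one six-membered aromatic ring of carbon only), on an amine nitrogen. The entering (3,5-dichlorophenyl)carbamoyl group keeps one six-membered aromatic ring of carbon only, as the group it replaces does.

Within the data shown here, no measured pair of compounds shows what a swap of this kind does in this assay, so the expectation rests on compound 1 at 10700 nM. No step beyond the usual scatter is expected in either direction, and the expected change is a 1.1-fold higher number from compound 1 to compound 4 (0.05 log units; within the scatter). For compound 4 the estimated value is 12000 nM, with an expected range of 4000 nM to 40000 nM.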

Compound 4, half-maximal inhibitory concentration: > 50000 nM
Compound 4 was reported as a limit; the forecaster's own chance of this, stated with the estimate: 30%; middle value at least 4.1-fold (0.61 log units) away from the limit.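

Within the data shown here, this is the first one-place comparison at the amine nitrogen, and in this assay the swap gives an at least 4.6-fold higher number from compound 1 to compound 4 (0.66 log units; beyond the scatter). The position is therefore sensitive to this change, even though the entering (3,5-dichlorophenyl)carbamoyl group keeps the six-membered aromatic ring of carbon only and the same counts of hydrogen-bond donors and acceptors as the group it replaces. The result for compound 4 is a limit of the assay and not a number, and the same limit appears elsewhere in the set: the limit of > 50000 nM in this assay, at which 2 of the 4 values shown sit.

The swap exchanges sulfur for oxygen and adds a second chlorine at once, so the compounds shown leave open which of the two carries the step. A carbamoyl group with only one chlorine on its phenyl ring, or a thiocarbamoyl group with two, would separate them.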